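A few compounds are considered here, and "the series" means these few. Any claim that something is new, unique, unknown or untested is made for them only; others in the source may bear on it.

Measured compounds:
- compound 1 `COc1ccc2[nH]c3c(c2c1)CCNC31CCN(Cc2ccc(Br)c(F)c2)CC1`; in an assay on FRT cells for positive allosteric modulation of Cystic fibrosis transmembrane conductance regulator variant N1303K (Homo sapiens), in the presence of a further agent that is not named here (on this read-out lower numbers stand for an effect already at smaller amounts and higher numbers for an effect only at larger amounts of compound), compound 1 gives 1800 nM
- compound 2 `COc1ccc2[nH]c3c(c2c1)CCNC31CCN(Cc2cc(F)ccc2F)CC1`; in this assay compound 2 gives 11100 nM

Compound 2 stands highest of the two numbers, separated from compound 1 by the step of a 6.2-fold higher number from compound 1 to compound 2 (0.79 log units; beyond the scatter). Compound 3 `COc1ccc2[nH]c3c(c2c1)CCNC31CCN(Cc2ccc(F)c(F)c2F)CC1` is not yet measured and differs from compound 2 by 2,3,4-trifluorophenyl in place of 2,5-difluorophenyl on a saturated chain carbon bound to an amine nitrogen in a ring. Among the measured compounds shown here, the one measured step, a 6.2-fold higher number from compound 1 to compound 2 (0.79 log units; beyond the scatter), concerns a different swap of the same group and offers no direct guide; it shows only that this position can shift the number beyond the scatter. A modest change is therefore expected, leaning lower, a 1.6-fold lower number from compound 2 to compound 3 (0.20 log units; within the scatter). For compound 3 in this assay a value of 7000 nM is estimated, between 2000 nM and 20000 nM.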

Compound 3, half-maximal effective concentration: 4100 nM
For compound 3 the middle estimate is 1.7-fold (0.23 log units) above the measured one; measured number inside the range.
By their numbers in this assay, from the lowest: compound 1; then compound 3; then compound 2.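

Changing only the fluorine pattern on the phenyl group at this position moves the number beyond the scatter (a 2.7-fold lower number from compound 2 to compound 3 (0.43 log units; beyond the scatter)). Even so, the 4-bromo-3-fluorophenyl group still gives the lowest number of the three (a 2.3-fold higher number from compound 1 to compound 3 (0.36 log units; beyond the scatter)). No measurement shown here explains this order.

The step to the 2,3,4-trifluorophenyl group changes both the number and the placement of the fluorines, so the two cannot be separated. As far as these compounds go, whether a phenyl group carrying chlorine, a nitrile or a methoxy group would match the bromine-bearing one remains open.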